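This account rests on a few compounds, and the source may have more. Where it says the series, first, only, none or still open, it means among the compounds named here.

Working notes on the series. Compound 1 `CCOC(=O)C1=CC(c2ccc(Cl)cc2)C2=C(CC(C)(C)CC2=O)N1` in an assay on isolated protein for inhibition of glucose-6-phosphatase catalytic subunit 1 (Homo sapiens), read by inositol phosphate accumulation, with a stated time of 30 min, tested at 100 uM (on this read-out lower numbers stand for less inhibition and higher numbers for more inhibition at the one concentration tested (going by the name of the read-out)), gives 11.3%. Compound 2 `CCOC(=O)C1=CC(c2ccc(Br)cc2)C2=C(CC(C)(C)CC2=O)N1` in this assay is reported as "not active" (no number reported), with no number given, so compound 2 stands without a value on this read-out. Compound 3 `COc1ccc(C2=CC(c3ccccc3)C3=C(CC(C)(C)CC3=O)N2)cc1` in this assay gives 8.34%. For the measured compounds named here, all three compounds sit low on this read-out, and no pair among them is separated by more than the usual scatter.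

Compound 4 `CCOC(=O)C1=CC(c2ccc(F)cc2)C2=C(CC(C)(C)CC2=O)N1` is the next member to be measured. It differs from compound 2 as follows: fluoro in place of bromo on an aromatic carbon. Given that compound 1 and compound 3 both lie low, and compound 2 shows nothing, no shift beyond the scatter is expected from compound 2 to compound 4 in this assay. Compound 4 is estimated to give about 8%, within a range of 0% to 20%.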

Compound 4, a percentage reported as inhibition, at one concentration (the size of the read-out at that concentration, not a potency): "not active" (no number reported)
No number was reported for compound 4, and the estimate cannot be compared.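

For the compounds shown here, compound 2 and compound 4 are both reported as not active, without a number, in this assay, so no step between them can be read. The compounds shown leave open whether 4-bromophenyl to 4-fluorophenyl changes inhibition at all. No further evidence bears on this result.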